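The source may report more compounds than this note shows. Statements on the series, on what has been measured and on what is new or still open speak of the compounds shown alone.

In a functional assay on HCT-116 cells (Homo sapiens) for antiproliferative activity, read by MTT assay, with a stated time of 72 h (a lower number here means a stronger inhibitor, a higher number a weaker inhibitor), three compounds sharing one core have been measured so far: compound 1 `O=C1O[C@H]([C@@H](O)Cn2cc(-c3cccc(O)c3)nn2)C(OCc2ccccc2)=C1OCc1ccccc1` gives 42900 nM, compound 2 `CCCCCc1ccc(-c2cn(C[C@H](O)[C@H]3OC(=O)C(OCc4ccccc4)=C3OCc3ccccc3)nn2)cc1` gives 13800 nM, and compound 3 `CCCCCCCCCCc1cn(C[C@H](O)[C@H]2OC(=O)C(OCc3ccccc3)=C2OCc2ccccc2)nn1` gives 28800 nM. Compound 3 cannot be told apart from compound 1 within the scatter, and its number is higher than that of compound 2.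

Compound 4 `O=C1O[C@H]([C@@H](O)Cn2cc(-c3cc(F)cc(F)c3)nn2)C(OCc2ccccc2)=C1OCc1ccccc1` carries 3,5-difluorophenyl in place of decyl on an aromatic carbon. The nearest evidence comes from the two measured exchanges between decyl and a substituted phenyl, a 1.5-fold lower number from compound 1 to compound 3 (0.17 log units; within the scatter) and a 2.1-fold higher number from compound 2 to compound 3 (0.32 log units; beyond the scatter). The two phenyl-bearing compounds themselves differ, with a 3.1-fold lower number from compound 1 to compound 2 (0.49 log units; beyond the scatter), so a phenyl group does not fix the number. Within the data shown here, no measured compound carries fluorine, which leaves this change without a direct precedent. No step beyond the scatter is therefore expected in this assay, and the expected step is a 1.0-fold higher number from compound 3 to compound 4 (0.02 log units; within the scatter). The estimated value for compound 4 is 30000 nM, with an expected range of 12000 nM to 70000 nM.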

Compound 4, half-maximal inhibitory concentration: 48200 nM
Beside the measured number, compound 4's estimate is 1.6-fold (0.21 log units) below it; the range from low to high includes it.
By their numbers in this assay, from the lowest: compound 2; then compounds 3, 1 and 4 (each within the scatter of the next).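

In this assay, replacing the open decyl chain with the 3,5-difluorophenyl ring at this aromatic carbon gives a 1.7-fold higher number from compound 3 to compound 4 (0.22 log units; within the scatter), and replacing 3-hydroxyphenyl with 3,5-difluorophenyl gives a 1.1-fold higher number from compound 1 to compound 4 (0.05 log units; within the scatter), so neither exchange can be told apart from the scatter. Only 4-pentylphenyl separates from the new group, with a 3.5-fold higher number from compound 2 to compound 4 (0.54 log units; beyond the scatter), which leaves compound 2 as the one compound among these four set apart from each of the others, though only modestly. Nothing measured here offers an explanation for these numbers.

Whether the advantage of compound 2 needs both the phenyl ring and its pentyl chain remains open, since a phenyl ring bearing a shorter chain such as ethyl is not among the compounds shown. An amine or a carboxylic acid on that ring also remains untested in the compounds shown.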